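This account rests on a few compounds, and the source may have more. Where it says the series, first, only, none or still open, it means among the compounds named here.

Measured so far:
Compound 1, `CCO/C(O)=C1\C(COCCN2C(=O)CNC2=O)=NC(C)=C(C(=O)OC)C1c1ccccc1Cl`, gives 31.6 nM.
Compound 2, `CCO/C(O)=C1\C(COCCn2nncc2C(N)=O)=NC(C)=C(C(=O)OC)C1c1cccc(Cl)c1Cl`, gives 15.9 nM.
Compound 3, `CCO/C(O)=C1\C(COCCN2CC(=O)N=C2N)=NC(C)=C(C(=O)OC)C1c1ccccc1Cl`, gives 20 nM.

All three numbers come from a functional assay (aorta) with Rattus norvegicus as the target; a higher number here means a weaker inhibitor, a lower number a stronger inhibitor. Compound 2 has the lowest number of the three, but its distance to compound 3 and to compound 1 each stays within the scatter, so the three compounds cannot be placed in order.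

Compound 4, `CCO/C(O)=C1\C(COCCN2CC(=O)NC2=O)=NC(C)=C(C(=O)OC)C1c1cccc(Cl)c1Cl`, is compound 2 with one change on the side chain: 2,4-dioxoimidazolidin-1-yl in place of 5-carbamoyl-1H-1,2,3-triazol-1-yl on a saturated chain carbon, two bonds along the chain from an oxygen on a saturated carbon.

Among the measured compounds shown here, only one measured step touches the same place. It runs a 1.6-fold lower number from compound 1 to compound 3 (0.20 log units; within the scatter), where a group of 7 heavy atoms with one five-membered non-aromatic ring with 2 hetero atoms replaced another of the same size and ring type. For the measured compounds named here, no measured step removes a five-membered aromatic ring, so the change from compound 2 to compound 4 is not matched by any measured pair.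

Given that the one swap at this place stayed within the scatter, compound 4 is expected to move little, a 1.3-fold higher number from compound 2 to compound 4 (0.10 log units; within the scatter), with no direction favoured in this assay. The estimate for compound 4 is 20 nM, between 8 nM and 50 nM.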

Compound 4, half-maximal inhibitory concentration: 3.16 nM
Compound 4: middle estimate off by 6.3-fold (0.80 log units), on the high side; measured number outside the range, below it.
By their numbers in this assay, from the lowest: compound 4; then compounds 2, 3 and 1 (each within the scatter of the next).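

In this assay, replacing the 5-carbamoyl-1H-1,2,3-triazol-1-yl group with the 2,4-dioxoimidazolidin-1-yl group gives a 5.0-fold lower number from compound 2 to compound 4 (0.70 log units; beyond the scatter) and clears the usual scatter of repeated measurements. Among the compounds shown here, the only earlier step at this place, a 1.6-fold lower number from compound 1 to compound 3 (0.20 log units; within the scatter), exchanged one non-aromatic five-membered ring for another and stayed within the scatter, so this is the first sign that the group on this chain can shift the number by a real margin, at least when an aromatic ring leaves and a non-aromatic one enters. Nothing measured here explains the shift.

The single step changes several things at once, including the ring type, the number of hydrogen-bond acceptors and the presence of the carbamoyl group, so the compounds shown cannot say which of these matters, or whether the same swap would give a similar step in compounds with one chlorine on the phenyl ring rather than two. On these data alone, it also remains open how an amine or a carboxylic acid at this place, or a longer chain carrying the 2,4-dioxoimidazolidin-1-yl ring, would compare with compound 4.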